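A Diethylamino Group Enters a Narrow Series

The compounds below may be only part of what the source reports. "The series", "measured", "known", "first", "only" and "open" are said of these compounds alone.

In a functional assay on HeLa cells (Homo sapiens) for antiproliferative activity, read by resazurin assay (a higher number here means a weaker inhibitor, a lower number a stronger inhibitor), compound 1 `CCSC(=S)SCC(=O)c1ccccc1` gives 5010 nM and compound 2 `[C-]#[N+]c1ccc(C(=O)CSC(=S)SCC)cc1` gives 7940 nM while compound 3 `CCSC(=S)SCC(=O)c1ccccc1C` gives 10000 nM on the same core, so compound 2 stands within the scatter of both others. Compound 4 `CCSC(=S)SCC(=O)c1ccc(N(CC)CC)cc1` differs from compound 2 by a group of 5 heavy atoms (4 carbon, 1 nitrogen; no ring) in place of a group of 2 heavy atoms (1 carbon, 1 nitrogen; no ring), on an aromatic carbon. Among the compounds with values here, two measured steps bear on this change: a 1.6-fold higher number from compound 1 to compound 2 (0.20 log units; within the scatter) for the group that leaves and a 2.0-fold higher number from compound 1 to compound 3 (0.30 log units; within the scatter) for methyl on an aromatic carbon. Both lie within the scatter, and neither brings in diethylamino. No step beyond the scatter is therefore expected in this assay for this change. The estimated step is a 1.1-fold lower number from compound 2 to compound 4 (0.05 log units; within the scatter) and is expected to stay within the scatter. Compound 4 is expected to read 7000 nM with a range of 2500 nM to 20000 nM.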

Compound 4, half-maximal inhibitory concentration: 3160 nM
Compound 4: the middle estimate sits 2.2-fold (0.35 log units) above what was measured; the measured number falls inside the stated range.
By their numbers in this assay, from the lowest: compounds 4, 1, 2 and 3 (each within the scatter of the next, the first and the last beyond it).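

The series shows its first step beyond the scatter in this assay with a 2.5-fold lower number from compound 2 to compound 4 (0.40 log units; beyond the scatter) when diethylamino replaces the group on this aromatic carbon, so the choice of group at this place can separate two compounds. Yet a 1.6-fold lower number from compound 1 to compound 4 (0.20 log units; within the scatter) stays within the scatter for diethylamino in place of hydrogen, so compound 4 cannot be set apart from compound 1. Nothing measured here accounts for the step.

On these data alone, whether a smaller amine such as dimethylamino, or a methoxy group, on this same carbon would read like compound 4 remains open. So does the effect of longer chains on the nitrogen.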